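Swapping methyl for trifluoromethyl on a shared core

This account rests on a few compounds, and the source may have more. Where it says the series, first, only, none or still open, it means among the compounds named here.

Measured compounds:
- compound 1, `CN1CCN(CCNCc2cn(-c3ccc(F)cc3F)nc2-c2ccc(Cl)cc2)CC1`, 19000 nM
- compound 2, `Cc1ccc(-c2nn(-c3ccc(F)cc3F)cc2CNCCN2CCN(C)CC2)cc1`, > 20000 nM
- compound 3, `Cc1ccccc1-c1nn(-c2ccccc2Cl)cc1CNCCN1CCN(C)CC1`, > 20000 nM

In an ADME assay on Huh-7 cells (Homo sapiens) for cytotoxicity (on this read-out lower numbers stand for higher toxicity in this test and higher numbers for lower toxicity in this test), compound 1 gives 19000 nM. Compound 2 gives > 20000 nM in this assay, which is a limit of the assay rather than a number. Compound 3 likewise gives > 20000 nM in this assay, again a limit of the assay. Compound 2 therefore stands at the top of what the test can report, as described by the limit of > 20000 nM in this assay, at which 2 of the 3 values shown sit.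

Compound 4, `CN1CCN(CCNCc2cn(-c3ccc(F)cc3F)nc2-c2ccc(C(F)(F)F)cc2)CC1`, is not yet measured. It differs from compound 2 in one place: trifluoromethyl in place of methyl on an aromatic carbon. Within the data shown here, the only measured step that resembles it is an at least 1.0-fold higher number from compound 1 to compound 2 (0.02 log units; that floor lies within the scatter), which exchanged chloro for methyl at the same aromatic carbon and stayed within the scatter. Because the limit of > 20000 nM in this assay, at which 2 of the 3 values shown sit, shows two of three values resting at the limit, little room remains for a visible change in either direction.

Compound 4 is therefore expected to show a number no higher from compound 2 to compound 4 (the limit leaves the size open), so the estimate for compound 4 in this assay is 20000 nM, with a range from 8000 nM to 40000 nM.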

Compound 4, half-maximal cytotoxic concentration: 20000 nM
Estimate against measurement, compound 4: no gap at the digits printed, within the range that was stated.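

At the aromatic carbon para to a large group, trifluoromethyl can now be compared with chloro, and the result is a 1.1-fold higher number from compound 1 to compound 4 (0.02 log units; within the scatter) in this assay, so these two groups cannot be told apart on this read-out. Compound 2 gives > 20000 nM in this assay, which is a limit of the assay and not a number. Trifluoromethyl in place of methyl, where 4 heavy atoms replace 1, gives a number no higher from compound 2 to compound 4 (the limit leaves the size open), and the size of this step cannot be read, because the values sit against the top of the test: the limit of > 20000 nM in this assay, at which 2 of the 4 values shown sit.

As far as these compounds go, it remains open whether a group of another kind at this carbon, such as an amine or a carboxylic acid, would give a clearly lower number in this assay. Also open, from the compounds shown here alone, is whether trifluoromethyl would behave the same way on a different core.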